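Cyclopropyl to isopropyl on two related fused cores

The source may report more compounds than this note shows. Statements on the series, on what has been measured and on what is new or still open speak of the compounds shown alone.

Measured compounds:
compound 1 `Cc1nn(C)c2nc(C3CC3)c(/C=C/[C@@H](O)C[C@@H](O)CC(=O)O)c(-c3ccc(F)cc3)c12` — 74.3%
compound 2 `Cc1nn(C)c2nc(C(C)C)c(/C=C/[C@@H](O)C[C@@H](O)CC(=O)O)c(-c3ccc(F)cc3)c12` — 48.1%
compound 3 `Cc1cc2nc(C3CC3)c(/C=C/[C@@H](O)C[C@@H](O)CC(=O)O)c(-c3ccc(F)cc3)n2n1` — 6.5%

In an in vivo functional assay on the whole organism for inhibition of 3-hydroxy-3-methylglutaryl-coenzyme A reductase (Rattus norvegicus), at a dose of 2 mg/kg by the oral route (a higher number here means a stronger effect of the compound at the dose given, a lower number a weaker effect), compound 1 gives 74.3%. Compound 2 carries the change isopropyl in place of cyclopropyl on an aromatic carbon on the core of compound 1, and in this assay compound 2 gives 48.1%, so the step of a number 26.2 percentage points lower from compound 1 to compound 2 (beyond the scatter). Compound 3 rests on a different core; the difference between the two cores is not broken down here. In this assay compound 3 gives 6.5%, the lowest of the three numbers.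

Compound 4 `Cc1cc2nc(C(C)C)c(/C=C/[C@@H](O)C[C@@H](O)CC(=O)O)c(-c3ccc(F)cc3)n2n1` is not yet measured. It differs from compound 3 by isopropyl in place of cyclopropyl on an aromatic carbon, the same kind of change as from compound 1 to compound 2, though the place is not the same: in compound 3 the six-membered aromatic ring holds 2 nitrogen and the group sits opposite the ring nitrogen, whereas in compound 1 the ring holds 1 nitrogen. Within the data shown here, the one measured instance of this change lowered the read-out. Because compound 3 already gives 6.5%, there is little room for a downward step of the earlier size, so a smaller step is expected: compound 4 is estimated at a number 4.5 percentage points lower from compound 3 to compound 4 (within the scatter). In this assay compound 4 is expected to give 2%, between -10% and 12%.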

Compound 4, a percentage reported as inhibition, in the whole organism at one dose (the size of the read-out at that dose, not a potency): -45.1%
The estimate for compound 4 lay 47.1 percentage points above the measured number; the whole stated range lies above it.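

In this assay, isopropyl in place of cyclopropyl lowers the read-out on both cores, but the size of the step does not carry over from one core to the other: the same change on two cores in this assay, a number 26.2 percentage points lower (beyond the scatter) from compound 1 to compound 2 and a number 51.6 percentage points lower (beyond the scatter) from compound 3 to compound 4, 25.4 percentage points apart, beyond the scatter of two such steps

On the second core the change gives a number 51.6 percentage points lower from compound 3 to compound 4 (beyond the scatter), so the direction seen on the core of compound 1 held while the size did not, and the step measured on one core gave no reliable size for the other. Among these compounds, with only two pairs, this shows that the change went the same way twice; it does not show why the steps differ or whether the same direction would hold on any further core, and these data do not explain the negative number of compound 4, -45.1%.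

The compounds shown leave open whether another group at this place, such as ethyl, tert-butyl or cyclobutyl, would behave like cyclopropyl or like isopropyl on either core. They also leave open whether the difference in step size would persist at other oral doses, since each compound is shown at a single dose.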